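Removing a Fluorine from Two Related Urea Compounds

This account rests on a few compounds, and the source may have more. Where it says the series, first, only, none or still open, it means among the compounds named here.

Compound 1 `COc1ccc(/C=N/NC(=O)Nc2ccc(Oc3ccnc4[nH]ccc34)c(F)c2)c(OC)c1OC` and compound 2 `COc1ccc(/C=N/NC(=O)Nc2ccc(Oc3ccnc4[nH]ccc34)cc2)c(OC)c1OC` share one core, while compound 3 `CN(C)CCn1cccc1/C=N/NC(=O)Nc1ccc(Oc2ccnc3[nH]ccc23)c(F)c1` and compound 4 `CN(C)CCn1cccc1/C=N/NC(=O)Nc1ccc(Oc2ccnc3[nH]ccc23)cc1` share another; the difference between the two cores is not broken down here. In a functional assay on A549 cells (Homo sapiens) for antiproliferative activity, read by MTT assay, with a stated time of 72 h (on this read-out higher numbers stand for weaker inhibition and lower numbers for stronger inhibition), compound 1 gives 1450 nM, and compound 2 gives 3340 nM. The change between them is hydrogen in place of fluoro on an aromatic carbon, and it produced a 2.3-fold higher number from compound 1 to compound 2 (0.36 log units; beyond the scatter). Compound 3 carries the same fluoro as compound 1, and in this assay compound 3 was reported as "not active" (no number reported), with no number attached. Compound 4 differs from compound 3 in one place. That difference is hydrogen in place of fluoro on an aromatic carbon. The surroundings described for this change are the same in both pairs, so it is the same change, only on a different core. Because compound 3 gave "not active" (no number reported) and because the step of a 2.3-fold higher number from compound 1 to compound 2 (0.36 log units; beyond the scatter) went toward weaker inhibition, compound 4 is expected to inhibit at least as weakly, with a high chance that this assay again reports no number. The estimate for compound 4 is 40000 nM, between 10000 nM and 150000 nM.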

Compound 4, half-maximal inhibitory concentration: "not active" (no number reported)
The entry for compound 4 holds no number; there is nothing to compare the estimate with.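

Going by these compounds alone, compound 3 and compound 4 were both reported as "not active" in this assay, with no number for either, so no step between them can be read. The compounds shown leave open whether replacing fluoro with hydrogen changes inhibition at all on the core of compound 3. No supporting evidence bears on this result.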